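Notes on the chalcone series: nitro to methoxy swap

A few compounds are considered here, and "the series" means these few. Any claim that something is new, unique, unknown or untested is made for them only; others in the source may bear on it.

Compound 1 `CCN(CC)c1ccc(/C=C/C(=O)c2ccc(OC)c3c2OC(C)(C)C=C3)cc1` gives 610 nM in a functional assay on SK-OV-3 cells (Homo sapiens) for antiproliferative activity, read by MTT assay, with a stated time of 24 h; a higher number here means a weaker inhibitor, a lower number a stronger inhibitor. Compound 3 `COc1ccc(C(=O)/C=C/c2ccc(C(F)(F)F)cc2)c2c1C=CC(C)(C)O2` returns only a limit in this assay, > 10000 nM, as recorded in the limit of > 10000 nM in this assay, at which 1 of the 3 values shown sits. Going by the values given here, the one measured step, an at least 16-fold higher number from compound 1 to compound 3 (1.21 log units; beyond the scatter), is the only guide to how a change on that aromatic ring moves the number. Compound 2 `COc1ccc(C(=O)/C=C/c2cccc([N+](=O)[O-])c2)c2c1C=CC(C)(C)O2` gives 9720 nM in this assay, the highest of the two numbers shown, with compound 1 at 610 nM standing far lower.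

Compound 4 `COc1ccccc1/C=C/C(=O)c1ccc(OC)c2c1OC(C)(C)C=C2` has not been measured. It differs from compound 2 by 2-methoxyphenyl in place of 3-nitrophenyl on a double-bonded chain carbon bound to a double-bonded chain carbon. Among the compounds with values here, no measured step changes a nitro for a methoxy group; the step from compound 1 to compound 3 bears only loosely, showing that a swap at this ring can shift the number by a large amount. Compound 2 already sits close to the limit, so a modest move downward is expected, a 2.4-fold lower number from compound 2 to compound 4 (0.39 log units; beyond the scatter), with wide uncertainty. Compound 4 is estimated at 4000 nM, between 1200 nM and 10000 nM.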

Compound 4, half-maximal inhibitory concentration: > 10000 nM
Compound 4 gave a limit, no number; the forecaster's own chance of this, stated with the estimate: 25%; at least 2.5-fold (0.39 log units) between middle value and limit.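

Compound 4 returns only a limit in this assay, > 10000 nM. The step is an at least 1.0-fold higher number from compound 2 to compound 4 (0.01 log units; that floor lies within the scatter), which gives a floor and no size, and that floor does not separate the two compounds, so 2-methoxyphenyl in place of 3-nitrophenyl on a double-bonded chain carbon bound to a double-bonded chain carbon brings no measurable gain. At this place 2-methoxyphenyl joins the groups that leave the number at the weak end, and among the compounds shown only compound 1, with its diethylamino group, stands clear of it: the limit of > 10000 nM in this assay, at which 2 of the 4 values shown sit.

The two limits leave compound 3 and compound 4 without any order between them. Also open, from the compounds shown here alone, is whether a smaller amine such as dimethylamino, or a carboxylic acid, on the same ring would keep a number near that of compound 1.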